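The source may report more compounds than this note shows. Statements on the series, on what has been measured and on what is new or still open speak of the compounds shown alone.

Compound 1 `c1ccc(-c2nnc(-c3c[nH]c4ccccc34)o2)cc1` and compound 2 `c1ccc(Cc2nnc(-c3c[nH]c4ccccc34)o2)cc1` share a core that carries two aromatic arms. In a functional assay on DU-145 cells (Homo sapiens) for cytotoxicity, read by MTT assay (on this read-out lower numbers stand for stronger inhibition and higher numbers for weaker inhibition), compound 1 reaches only the limit of the assay, > 1000000 nM. In this assay compound 2 likewise stops at the assay limit, > 1000000 nM. The step that the two limits leave unreadable from compound 1 to compound 2 is therefore unreadable, since (the limit of > 1000000 nM in this assay, at which 2 of the 2 values shown sit). Among the compounds with values here, compound 2 thus stands at the limit, alongside the one other value, which is also a limit. Compound 3 `c1ccc2c(-c3nnc(-c4ccncc4)o3)c[nH]c2c1` differs from compound 2 by pyridin-4-yl in place of benzyl on an aromatic carbon. Within the data shown here, no measured step bears on this change, as the only step recorded, from phenyl to benzyl, could not be read. With both known values at the limit, compound 3 is expected to remain near that limit, giving an expected step of a number no higher from compound 2 to compound 3 (the limit leaves the size open) in this assay, none beyond the scatter. The estimate for compound 3 is 1000000 nM, in a range from 200000 nM to 5000000 nM.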

Compound 3, half-maximal inhibitory concentration: 20400 nM
Estimate against measurement, compound 3: 49-fold (1.69 log units) above; the measured number lies below the stated range.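

The position on the shared core is not silent in this assay: pyridin-4-yl in place of benzyl gives an at least 49-fold lower number from compound 2 to compound 3 (1.69 log units; beyond the scatter), and pyridin-4-yl in place of phenyl gives an at least 49-fold lower number from compound 1 to compound 3 (1.69 log units; beyond the scatter). Of the three groups shown at this position, only pyridin-4-yl has a hetero atom in its six-membered aromatic ring and counts a hydrogen-bond acceptor. Both steps are bounds and not full sizes because the two starting compounds stand at a limit: the limit of > 1000000 nM in this assay, at which 2 of the 3 values shown sit.

The step between compound 1 and compound 2 still cannot be read. Open too, on these data alone, is whether the ring nitrogen needs this exact placement, as a pyridin-3-yl or pyridin-2-yl group would test, and whether an amine or a carboxylic acid on the same aromatic carbon would also give a measurable number.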